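The source may hold more compounds than are shown below. What is called first, only, known or untested is meant among the compounds shown, and "the series" means these compounds.

In a functional assay on MRC5 cells (Homo sapiens) (a higher number here means that more compound is tolerated, a lower number that less compound is tolerated), three compounds have been measured so far. Compound 1 `O=C1c2ccccc2N(Cc2ccc([N+](=O)[O-])cc2)S(=O)(=O)N1Cc1ccc([N+](=O)[O-])cc1` gives 53000 nM. Compound 3 `O=S1(=O)N=C(OCc2ccccc2-c2ccccc2)c2ccccc2N1Cc1ccccc1-c1ccccc1` gives 47000 nM. Compound 2 `O=C1c2ccccc2N(Cc2ccc([N+](=O)[O-])cc2)S(=O)(=O)N1Cc1ccccc1` does not give a number at all but a limit of the assay, > 59000 nM. The step of an at least 1.1-fold higher number from compound 1 to compound 2 (0.04 log units; that floor lies within the scatter) is therefore only a floor, and it sits within the usual scatter; the reason compound 2 can only be placed this way is the limit of > 59000 nM in this assay, at which 1 of the 3 values shown sits. On the numbers shown, compound 2 thus stands at the tolerated end, with compound 1 and compound 3 close by rather than clearly apart from it.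

The unmeasured compound 4 `C#CCCN1c2ccccc2C(=O)N(Cc2ccccc2)S1(=O)=O` differs from compound 2 in one place: propargyl in place of 4-nitrophenyl on a saturated chain carbon bound to a sulfonamide nitrogen in a ring. Within the data shown here, the only measured step touching this position is the one from compound 1 to compound 2, which was an at least 1.1-fold higher number from compound 1 to compound 2 (0.04 log units; that floor lies within the scatter), and no measured step covers the swap of 4-nitrophenyl for propargyl itself. With all three measured values lying in one narrow band, the expectation for compound 4 is a step of an at least 1.0-fold lower number from compound 2 to compound 4 (0.03 log units; that floor lies within the scatter), nothing beyond the scatter. Compound 4 is accordingly estimated at 55000 nM, within a range from 28000 nM to 110000 nM, with a real chance that this assay again reports only a limit.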

Compound 4, half-maximal cytotoxic concentration: 77000 nM
Estimate against measurement, compound 4: 1.4-fold (0.15 log units) below, and the stated range covers the measured number.
By their numbers in this assay, from the lowest: compounds 3, 1 and 4 (each within the scatter of the next).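

No new step can be read in this assay: the comparison from compound 2 to compound 4 stays unreadable, because compound 2 carries a limit and not a number: the limit of > 59000 nM in this assay, at which 1 of the 4 values shown sits.

The compounds shown leave open whether propargyl in place of 4-nitrophenyl changes the concentration of compound tolerated at all, and by how much.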